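This account rests on a few compounds, and the source may have more. Where it says the series, first, only, none or still open, it means among the compounds named here.

Measured compounds in a functional assay on HeLa cells (Homo sapiens) for antiproliferative activity, read by cell counting, with a stated time of 2 days; a lower number here means a stronger inhibitor, a higher number a weaker inhibitor:
- compound 1, `COc1cc(C(=O)c2sc(Nc3ccc(F)cc3)nc2N)cc(OC)c1OC`: 440 nM
- compound 2, `COc1cc(C(=O)c2sc(Nc3ccc(C)cc3)nc2N)cc(OC)c1OC`: 86 nM
- compound 3, `Nc1nc(Nc2ccc(F)cc2)sc1C(=O)c1ccccc1`: > 10000 nM, which is a limit of this assay and not a number.

Compound 1 and compound 2 share one core and differ in a single place: methyl in place of fluoro on an aromatic carbon. This change gave a 5.1-fold lower number from compound 1 to compound 2 (0.71 log units; beyond the scatter) in this assay. Compound 3 carries a different core; the difference between the two cores is not broken down here. For compound 3 this assay reports only (the limit of > 10000 nM in this assay, at which 1 of the 3 values shown sits).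

Compound 4, `Cc1ccc(Nc2nc(N)c(C(=O)c3ccccc3)s2)cc1`, is not yet measured. It stands to compound 3 as compound 2 stands to compound 1: methyl in place of fluoro on an aromatic carbon. The place lines of the two changes read the same word for word, so this is the same change, made on the second core.

Going by these compounds, whether the step seen from compound 1 to compound 2 carries over to the second core is untested. Compound 3 sits at the limit, so a step of the earlier size would leave compound 4 near the upper edge of what this assay reports, and a value at the limit again remains likely. The expected step from compound 3 to compound 4 is an at least 1.2-fold lower number from compound 3 to compound 4 (0.09 log units; that floor lies within the scatter). For compound 4 in this assay the estimate is 8000 nM, expected to fall between 2000 nM and 30000 nM.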

Compound 4, half-maximal inhibitory concentration: 900 nM
Estimate against measurement, compound 4: 8.9-fold (0.95 log units) above; the measured number lies below the stated range.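

Methyl in place of fluoro on an aromatic carbon, read as 4-fluorophenyl to 4-methylphenyl, lowers the number on the second core as it did on the first, with an at least 11-fold lower number from compound 3 to compound 4 (1.04 log units; beyond the scatter) in this assay. The direction of the step therefore carries over in the two pairs shown, but its size on the second core is not fixed, and no claim holds that the change does more on one core than on the other: the same change on two cores in this assay, a 5.1-fold lower number (0.71 log units; beyond the scatter) from compound 1 to compound 2 and an at least 11-fold lower number (1.04 log units; beyond the scatter) from compound 3 to compound 4; the limit leaves it open whether they differ. For compound 3 the value (> 10000 nM) is a limit of the assay and not a number, and two pairs on two cores show nothing about any further core in the series.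

Going by these compounds, whether the gain belongs to methyl alone stays open, since the para position of that aromatic ring is covered here only by fluoro and methyl, and chloro, trifluoromethyl, an amine or a longer chain such as propyl would show how far the step extends. Also open, on these data alone, is which part of the difference between the two cores sets the level on which the change acts.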